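A few compounds are considered here, and "the series" means these few. Any claim that something is new, unique, unknown or untested is made for them only; others in the source may bear on it.

Measured compounds:
- compound 1 `CCCC(=O)N1CCC(CN2CC[C@H](NC(=O)c3cc(Cl)c(N)cc3OC)[C@H](OC)C2)CC1` — in an assay on COS-7 cells for displacement of a labelled ligand from 5-hydroxytryptamine receptor 4 (Homo sapiens), read by scintillation counting, with a stated time of 30 min (on this read-out higher numbers stand for weaker inhibition and lower numbers for stronger inhibition), compound 1 gives 178 nM
- compound 2 `CCC(=S)N1CCC(CN2CC[C@H](NC(=O)c3cc(Cl)c(N)cc3OC)[C@H](OC)C2)CC1` — in this assay compound 2 gives 593 nM

Compound 2 stands at the higher of the two numbers; its nearest neighbour is compound 1, and the step of a 3.3-fold higher number from compound 1 to compound 2 (0.52 log units; beyond the scatter) lies beyond the scatter. Compound 3 `CCC(=O)N1CCC(CCN2CC[C@H](NC(=O)c3cc(Cl)c(N)cc3OC)[C@H](OC)C2)CC1` differs from compound 2 by a group of 11 heavy atoms (9 carbon, 1 nitrogen, 1 oxygen; one six-membered non-aromatic ring with 1 hetero atom) in place of a group of 10 heavy atoms (8 carbon, 1 nitrogen, 1 sulfur; one six-membered non-aromatic ring with 1 hetero atom), on a saturated chain carbon bound to an amine nitrogen in a ring. Among the measured compounds shown here, the only measured step that bears on this change is a 3.3-fold higher number from compound 1 to compound 2 (0.52 log units; beyond the scatter), which runs in the opposite sense, from the oxygen-bearing acyl group to the sulfur-bearing one. For the measured compounds named here, compound 3 brings the oxygen back, and on that ground a drop of about that size is expected; no measured pair speaks to the longer chain between the two rings, so that part of the change is left open. Compound 3 is therefore expected to land near compound 1, the step of a 3.0-fold lower number from compound 2 to compound 3 (0.47 log units; beyond the scatter) being the estimate, with compound 3 put at 200 nM within a range of 70 nM to 600 nM.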

Compound 3, half-maximal inhibitory concentration: 805 nM
Beside the measured number, compound 3's estimate is 4.0-fold (0.60 log units) below it; measured number outside the range, above it.
By their numbers in this assay, from the lowest: compound 1; then compounds 2 and 3 (each within the scatter of the next).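

In this assay, the return to an oxygen-bearing acyl group does not bring the number back towards that of compound 1: the change from the sulfur-bearing group to (1-propanoylpiperidin-4-yl)methyl gives a 1.4-fold higher number from compound 2 to compound 3 (0.13 log units; within the scatter). With the carbonyl kept, (1-propanoylpiperidin-4-yl)methyl in place of 1-(propylcarbonyl)piperidin-4-yl, on a saturated chain carbon bound to an amine nitrogen in a ring, gives a 4.5-fold higher number from compound 1 to compound 3 (0.66 log units; beyond the scatter), so this change alone carries a step beyond the scatter. Nothing at hand accounts for that step.

Left open is how much of it belongs to the longer chain between the two rings and how much to the shorter acyl group, as the two change together here. Also open, from the compounds shown here alone, is how a still longer chain, or a sulfonyl group on the amine nitrogen in the ring, would read.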